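The compounds below may be only part of what the source reports. "The series", "measured", "known", "first", "only" and "open" are said of these compounds alone.

Measured compounds in a functional assay on the whole organism (strain Wistar Albino) for inhibition, with Rattus norvegicus as the target, read by paw edema, with a stated time of 1 h, at a dose of 20 mg/kg; a lower number here means less inhibition, a higher number more inhibition at the dose given (going by the name of the read-out):
compound 1, `COc1ccc(Cc2nnc3n2NC(c2ccc[nH]2)S3)cc1OC`, gives 13.2%
compound 2, `Cc1occc1-c1nnc2n1NC(c1ccc[nH]1)S2`, gives 13.7%
compound 3, `COc1ccc(Cc2nnc3n2NC(c2cccn2C)S3)cc1OC`, gives 13.4%

Compound 1 and compound 3 share a core and differ only by methyl in place of hydrogen on an aromatic nitrogen. That change gave a number 0.2 percentage points higher from compound 1 to compound 3 (within the scatter). Compound 2 rests on a different core; how the two cores differ is not broken down here. All three measured values lie within the scatter of one another, so no order among compound 1, compound 2 and compound 3 can be read from them in this assay.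

Compound 4, `Cc1occc1-c1nnc2n1NC(c1cccn1C)S2`, has not yet been measured. Within the data shown here, it is related to compound 2 by methyl in place of hydrogen on an aromatic nitrogen, which is the same change as the one from compound 1 to compound 3, made at the same place of the same ring. On that basis the step is expected to be small: the change expected from compound 2 to compound 4 is a number 0.2 percentage points higher from compound 2 to compound 4 (within the scatter), resting on the step of a number 0.2 percentage points higher from compound 1 to compound 3 (within the scatter) seen with the other core. Compound 4 is therefore expected to give about 13.9% in this assay. For compound 4 the expected range runs from 8% to 20%.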

Compound 4, a percentage reported as inhibition, in the whole organism at one dose (the size of the read-out at that dose, not a potency): 14.6%
Compound 4: the middle estimate sits 0.7 percentage points below what was measured; the measured number falls inside the stated range.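

In this assay, the change from 1H-pyrrol-2-yl to 1-methyl-1H-pyrrol-2-yl gives a number 0.9 percentage points higher from compound 2 to compound 4 (within the scatter). Set beside the earlier step, the change carries from one core to the other with no difference that can be read: the same change on two cores in this assay, a number 0.2 percentage points higher (within the scatter) from compound 1 to compound 3 and a number 0.9 percentage points higher (within the scatter) from compound 2 to compound 4, 0.7 percentage points apart, within the scatter of two such steps

This shows that on both cores, at this one dose and time, methyl in place of hydrogen on an aromatic nitrogen leaves the read-out within the scatter; it does not show that a step of real size would carry over, since the agreement is only between two small steps, and two cores say nothing about other cores in the series.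

Still open, from the compounds shown here alone, is whether a group other than methyl on that aromatic nitrogen, such as an ethyl group, a longer chain, or a chain ending in an amine or a carboxylic acid, would move the read-out beyond the scatter. Also open, going by these compounds, is whether the two cores would stay this close at other doses or stated times.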